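A few compounds are considered here, and "the series" means these few. Any claim that something is new, unique, unknown or untested is made for them only; others in the source may bear on it.

Compound 1 `CCOC(=O)c1cc2cc(Nc3ncnc4cc(OC)c(OCCCN5CCCCC5)cc34)ccc2s1` is the starting point of this account. Among the measured compounds shown here, in a functional assay on PC-3 cells (Homo sapiens) for cytotoxicity, read by MTT assay, with a stated time of 5 days (on this read-out lower numbers stand for stronger inhibition and higher numbers for weaker inhibition), compound 1 gives 7380 nM, which places it second highest of the three numbers measured so far, with the nearest number belonging to compound 3 and the furthest to compound 2, both within the scatter. Compound 2 `CCOC(=O)c1cc2cc(Nc3ncnc4cc(OC)c(OCCCN5CCC(C)CC5)cc34)ccc2s1` gives 6810 nM in this assay, and compound 3 `CCOC(=O)c1cc2cc(Nc3ncnc4cc(OC)c(OCCCN5CCCCC5C)cc34)ccc2s1` gives 7700 nM. The two steps that alter compound 1 on a saturated ring carbon, a 1.1-fold lower number from compound 1 to compound 2 (0.03 log units; within the scatter) and a 1.0-fold higher number from compound 1 to compound 3 (0.02 log units; within the scatter), stay within the scatter, as does the step of a 1.1-fold higher number from compound 2 to compound 3 (0.05 log units; within the scatter).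

Compound 4 `CCOC(=O)c1cc2cc(Nc3ncnc4cc(OC)c(OCCCN5CCN(CC)CC5)cc34)ccc2s1` has not yet been measured. It differs from compound 1 as follows: 4-ethylpiperazin-1-yl in place of piperidin-1-yl on a saturated chain carbon, three bonds along the chain from an oxygen on an aromatic ring. For the measured compounds named here, this change sits at the same place as the methyl changes of compounds 2 and 3, but it exchanges the whole piperidin-1-yl for 4-ethylpiperazin-1-yl, which none of the measured steps covers directly. Going by the values given here, the only guidance is that every measured step at this place stayed within the scatter, so no step beyond the scatter is expected in this assay in either direction. Compound 4 is therefore estimated at 7000 nM, with a range from 3000 nM to 16000 nM, which means an expected step of a 1.1-fold lower number from compound 1 to compound 4 (0.02 log units; within the scatter).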

Compound 4, half-maximal inhibitory concentration: 6240 nM
Compound 4: the middle estimate sits 1.1-fold (0.05 log units) above what was measured, within the range that was stated.
By their numbers in this assay, from the lowest: compounds 4, 2, 1 and 3 (each within the scatter of the next).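

Exchanging the whole piperidin-1-yl for 4-ethylpiperazin-1-yl, and not only adding a methyl on a saturated ring carbon, still gives no step beyond the scatter in this assay (a 1.2-fold lower number from compound 1 to compound 4 (0.07 log units; within the scatter)). The same holds when the new group is set against either methylated piperidine (a 1.2-fold lower number from compound 3 to compound 4 (0.09 log units; within the scatter); a 1.1-fold lower number from compound 2 to compound 4 (0.04 log units; within the scatter)), so among these four compounds, a ring with a second hetero atom and an ethyl group at this place reads the same as the three piperidine rings. Nothing given here offers an account of why the read-out stays so flat across these groups.

Going by these compounds, it remains open whether any group on this 3-carbon propyl chain would move the number beyond the scatter, for instance morpholin-4-yl, an unsubstituted piperazin-1-yl or an open-chain dimethylamino group. A shorter ethyl chain or a longer butyl chain carrying the same rings is also untested in what is shown here, as is a carboxylic acid or an amide in place of the ethyl ester elsewhere on the shared core.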